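Swapping One Arm of an Inactive Pair

A few compounds are considered here, and "the series" means these few. Any claim that something is new, unique, unknown or untested is made for them only; others in the source may bear on it.

Compound 2 `Cc1cc(NC(=O)Nc2ncccc2C)c2ccccc2n1` is one of two compounds already tested. In an ADME assay on HepG2 cells (Homo sapiens) for cytotoxicity, with a stated time of 72 h (a lower number here means that less compound is needed, a higher number that more compound is needed for the effect), compound 2 reaches only the limit of the assay, > 25000 nM. Compound 1 `COc1ccc(NC(=O)Nc2cc(C)nc3ccccc23)cc1F` likewise gives only a limit in this assay, > 25000 nM. For the measured compounds named here, both known values therefore sit at the limit of > 25000 nM in this assay, at which 2 of the 2 values shown sit, so no step between measured compounds can be drawn. Compound 3 `Cc1cc(NC(=O)Nc2cccc(Cl)c2)c2ccccc2n1` is the untested partner: 3-chlorophenyl in place of 3-methylpyridin-2-yl on an amide-type nitrogen. With nothing but limits to go on, the expected step that the limit leaves unreadable from compound 2 to compound 3 is none beyond the scatter. Compound 3 is estimated at 30000 nM in this assay, within 10000 nM to 100000 nM, most likely reported again as a limit.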

Compound 3, half-maximal effective concentration: 19000 nM
Compound 3: the middle estimate sits 1.6-fold (0.20 log units) above what was measured; the range from low to high includes it.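

In this assay, for the compounds shown here, compound 3 gives 19000 nM, the first value here that is a real number and not a limit. Placing 3-chlorophenyl instead of 3-methylpyridin-2-yl on the amide-type nitrogen therefore gives an at least 1.3-fold lower number from compound 2 to compound 3 (0.11 log units; that floor lies within the scatter), so this change cannot yet be said to matter. The comparison stays coarse, since most values still stand at a limit: the limit of > 25000 nM in this assay, at which 2 of the 3 values shown sit.

From the compounds shown here alone, it remains open whether an arm carrying an amine or a carboxylic acid at this place would move the number beyond the scatter. Going by these compounds, the effect of changing the shared core also remains open.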